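The source may hold more compounds than are shown below. What is called first, only, known or untested is meant among the compounds shown, and "the series" means these compounds.

Compound 3 `Cc1ccc(-c2cc(-c3ccc(Cl)o3)cc(-c3ccsc3)n2)o1` reaches only a limit of the assay: in a functional assay on HCT-15 cells (Homo sapiens) for cytotoxicity, in the presence of a further agent that is not named here (a lower number here means a stronger inhibitor, a higher number a weaker inhibitor), compound 3 gives > 50000 nM. Compound 1 `Clc1ccc(-c2cc(-c3cccnc3)nc(-c3ccsc3)c2)o1` likewise shows only a limit, > 50000 nM in this assay. Compound 2 `Clc1ccc(-c2cc(-c3cccs3)nc(-c3ccccc3Cl)c2)o1` gives a number, 6190 nM in this assay. The change now is pyridin-2-yl in place of 5-methylfuran-2-yl on an aromatic carbon, giving compound 4 `Clc1ccc(-c2cc(-c3ccsc3)nc(-c3ccccn3)c2)o1`. Among the compounds with values here, the one measured step at this place, a step that the two limits leave unreadable from compound 1 to compound 3, cannot be read because of the limit of > 50000 nM in this assay, at which 2 of the 3 values shown sit. Within the data shown here, no measured step therefore shows how a pyridin-2-yl there behaves. Among the measured compounds shown here, the only guide is that compound 1, which carries a pyridin-3-yl at that place, sits at the limit > 50000 nM. Compound 4 is therefore expected to sit at or beyond that limit too, an expected step that the limit leaves unreadable from compound 3 to compound 4. The estimate for compound 4 in this assay is 60000 nM, between 20000 nM and 200000 nM.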

Compound 4, half-maximal inhibitory concentration: > 50000 nM
Compound 4: a limit, no number; the forecaster's own chance of this, stated with the estimate: 75%; the middle value does not contradict the limit.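

Within the data shown here, compound 4 also gives only a limit, so no step between compound 1, compound 3 and compound 4 can be read in this assay: the limit of > 50000 nM in this assay, at which 3 of the 4 values shown sit. The compounds shown leave open how pyridin-2-yl, pyridin-3-yl and 5-methylfuran-2-yl truly compare at this place.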